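A few compounds are considered here, and "the series" means these few. Any claim that something is new, unique, unknown or untested is made for them only; others in the source may bear on it.

Measured in a functional assay on PC-3 cells (Homo sapiens) for cytotoxicity, read by MTT assay, with a stated time of 72 h; a lower number here means a stronger inhibitor, a higher number a weaker inhibitor:
- compound 1 `O=C(/C=C/c1cccc(Cl)c1Cl)Nc1cc2c(Nc3ccc(F)c(Cl)c3)ncnc2cc1O[C@H]1CCOC1`: 27500 nM
- compound 2 `COc1cc2ncnc(Nc3ccc(F)c(Cl)c3)c2cc1NC(=O)/C=C/c1ccccc1[N+](=O)[O-]`: 14300 nM
- compound 3 `O=C(/C=C/c1cc(Br)c(O)c(Br)c1)Nc1cc2c(Nc3ccc(F)c(Cl)c3)ncnc2cc1O[C@H]1CCOC1`: 25500 nM

On these numbers, compound 3 at 25500 nM lies within the usual scatter of both other compounds, so the three cannot be ranked. Compound 4 `O=C(/C=C/c1ccccc1[N+](=O)[O-])Nc1cc2c(Nc3ccc(F)c(Cl)c3)ncnc2cc1O[C@H]1CCOC1` differs from compound 3 in one place: 2-nitrophenyl in place of 3,5-dibromo-4-hydroxyphenyl on a double-bonded chain carbon bound to a double-bonded chain carbon. Within the data shown here, the only measured step at that place is a 1.1-fold lower number from compound 1 to compound 3 (0.03 log units; within the scatter), which shows no real change. Though it differs from compound 4 elsewhere, compound 2 also carries 2-nitrophenyl and gives 14300 nM. No step beyond the scatter is therefore expected in this assay. The estimate means a 1.3-fold lower number from compound 3 to compound 4 (0.11 log units; within the scatter), an expected step of small size. For compound 4 the estimated value is 20000 nM, with an expected range from 10000 nM to 40000 nM.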

Compound 4, half-maximal inhibitory concentration: 7760 nM
The estimate for compound 4 lay 2.6-fold (0.41 log units) above the measured number; the measured number lies below the stated range.
By their numbers in this assay, from the lowest: compounds 4, 2, 3 and 1 (each within the scatter of the next, the first and the last beyond it).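

In this assay the group on this double-bonded chain carbon can matter: the swap to 2-nitrophenyl gives a 3.3-fold lower number from compound 3 to compound 4 (0.52 log units; beyond the scatter) and also a 3.5-fold lower number from compound 1 to compound 4 (0.55 log units; beyond the scatter) where the earlier halogenated pair showed only a 1.1-fold lower number from compound 1 to compound 3 (0.03 log units; within the scatter) here. Oxolan-3-yl in place of methyl on the oxygen, by contrast, gives a 1.8-fold lower number from compound 2 to compound 4 (0.27 log units; within the scatter) and so shows no real change. Nothing available explains the shift seen with 2-nitrophenyl. Still open, on these data alone, is whether an amine or a carboxylic acid on that phenyl ring, in place of the nitro group, would do as well.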